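Three flat points and a nitrile where a carboxy was

The compounds below may be only part of what the source reports. "The series", "measured", "known", "first", "only" and "open" are said of these compounds alone.

Compound 1 `COc1ccc(-c2cc3c(OC)cc(OC)cc3n(C)c2=O)cc1`, compound 2 `COc1ccc(-c2cc3c(OC)cc(OC)cc3n(CC(=O)OCc3ccccc3)c2=O)cc1` and compound 3 `COc1ccc(-c2cc3c(OC)cc(OC)cc3n(CC(=O)O)c2=O)cc1` share one core and differ only in the group carried on a saturated chain carbon bound to an aromatic nitrogen. In a functional assay on U-373MG ATCC cells for cytotoxicity against U373 MG (Homo sapiens), read by colorimetric assay and MTT assay (on this read-out higher numbers stand for weaker inhibition and lower numbers for stronger inhibition), compound 1 gives 10000 nM, compound 2 gives 10000 nM and compound 3 gives 10000 nM. The steps between them are all flat: no change at the digits printed from compound 1 to compound 2 (within the scatter), no change at the digits printed from compound 1 to compound 3 (within the scatter) and no change at the digits printed from compound 2 to compound 3 (within the scatter). Among the measured compounds shown here, compound 3 therefore stands level with both of its neighbours, with no step out of the scatter in either direction.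

Compound 4 `COc1ccc(-c2cc3c(OC)cc(OC)cc3n(CCC#N)c2=O)cc1` is the next member. Its difference from compound 3 is cyanomethyl in place of carboxy on a saturated chain carbon bound to an aromatic nitrogen. The two steps that bear on this change are the ones that also alter the group at this place, from compound 1 to compound 3 and from compound 2 to compound 3, and both were flat. For the measured compounds named here, no measured step involves a cyanomethyl group, so nothing seen so far points to a move in this assay beyond the scatter. The step from compound 3 to compound 4 is expected to be no change at the digits printed from compound 3 to compound 4 (within the scatter). Compound 4 is expected to give 10000 nM, with a range from 5000 nM to 20000 nM.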

Compound 4, half-maximal inhibitory concentration: 10000 nM
Beside the measured number, compound 4's estimate shows no gap at the digits printed; measured number inside the range.
By their numbers in this assay, from the lowest: compounds 1, 2, 3 and 4 (each within the scatter of the next).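

In this assay, the swap on a saturated chain carbon bound to an aromatic nitrogen gives no change at the digits printed from compound 3 to compound 4 (within the scatter), so losing the hydrogen-bond donor of the carboxy group and bringing in a triple bond leaves the read-out level. Cyanomethyl also holds level against the two other groups at this place, with no change at the digits printed from compound 2 to compound 4 (within the scatter) when it stands in place of benzyloxycarbonyl and no change at the digits printed from compound 1 to compound 4 (within the scatter) when it stands in place of hydrogen, so hydrogen, benzyloxycarbonyl, carboxy and cyanomethyl now all read alike here, and none of the four compounds goes against that. Nothing available speaks to why this position stays so flat across these groups.

Going by these compounds, whether any group at this place can move the number out of the scatter remains open, since an amine, a hydroxyl or a longer carbon chain in this spot could still behave differently from the four seen so far. The shared core is also the same in all four compounds, so what a change to the methoxy groups would do in this assay is equally unknown.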